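The compounds below may be only part of what the source reports. "The series", "measured", "known", "first", "only" and "open" are said of these compounds alone.

Notes on the series. Compound 1 `FC(F)(F)c1ccc(NCc2cn(-c3ccccc3)nc2-c2ccc(Br)cc2)cc1` was tested in an ADME assay on Vero 76 cells (Chlorocebus sabaeus) for cytotoxicity, read by MTT assay, with a stated time of 96 h (a lower number here means that less compound is tolerated, a higher number that more compound is tolerated), and gives 28000 nM. Compound 2 `Clc1ccc(NCc2cn(-c3ccccc3)nc2-c2ccc(Cl)cc2)cc1` gives 90000 nM in this assay, a higher number than compound 1 and beyond the usual scatter. Compound 3 `Clc1ccc(NCc2cn(-c3ccccc3)nc2-c2ccc(Br)cc2)cc1` gives 43000 nM; > 100000 nM (2 entries) in this assay. Of these several entries, (the several entries of compound 3 in this assay, 43000 nM; > 100000 nM (2 entries)), two are limits of the assay and not numbers, and only the single numerical entry can be compared. On the numbers shown, compound 1 stands lowest of the two compounds that give a number, with compound 2 as the nearest.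

Compound 4 `Cc1ccc(-c2nn(-c3ccccc3)cc2CNc2ccc(C(F)(F)F)cc2)cc1` has not yet been measured in this assay. It differs from compound 1 in one place: methyl in place of bromo on an aromatic carbon. Cut one bond further out, the change reads 4-bromophenyl to 4-methylphenyl. Among the compounds with values here, no step between measured compounds isolates this change, so nothing in the data shows its size or direction. For compound 4 a number close to that of compound 1 is expected. This estimate means a step of a 1.3-fold higher number from compound 1 to compound 4 (0.10 log units; within the scatter), expected to stay within the scatter. Compound 4 is estimated at 35000 nM in this assay, with a range from 15000 nM to 90000 nM.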

Compound 4, half-maximal cytotoxic concentration: 45000 nM
Compound 4: the middle estimate sits 1.3-fold (0.11 log units) below what was measured; measured number inside the range.
By their numbers in this assay, from the lowest: compounds 1, 4 and 2 (each within the scatter of the next, the first and the last beyond it).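

In this assay, within the data shown here, the change from 4-bromophenyl to 4-methylphenyl gives the first step that isolates one change: a 1.6-fold higher number from compound 1 to compound 4 (0.21 log units; within the scatter). Among these compounds, at this place, on an aromatic carbon para to a large group, the earlier compounds carried only bromo or chloro, so compound 4 is the first to show a carbon group there, and with methyl the number stays within the scatter of compound 1. This rests on a single pair, and nothing at hand gives a reason for the step.

As far as these compounds go, whether an amine, a carboxylic acid or a longer chain such as propyl at this place would also leave the number in this assay within the scatter stays open. Also open, from the compounds shown here alone, is whether methyl in place of bromo reads the same in compound 3, which carries chloro where compound 1 carries trifluoromethyl.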